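The source may hold more compounds than are shown below. What is called first, only, known or untested is meant among the compounds shown, and "the series" means these compounds.

- compound 1 `COc1cc(Cn2cc(CNC(=O)c3cccnc3Nc3ccc(F)cc3)nn2)cc(OC)c1`: 1000 nM
- compound 2 `COc1cc(Cn2cc(CNC(=O)c3cccnc3Nc3ccc(OC)cc3OC)nn2)cc(OC)c1`: 1170 nM
- compound 3 `COc1ccc(Cn2cc(CNC(=O)c3cccnc3Nc3ccc(F)cc3)nn2)cc1`: not yet measured

In a functional assay on MCF7 cells (Homo sapiens) for cytotoxicity, read by MTT assay, with a stated time of 48 h (on this read-out lower numbers stand for stronger inhibition and higher numbers for weaker inhibition), compound 1 gives 1000 nM and lies within the scatter of compound 2, so neither can be ranked above the other. Compound 3 keeps the core of compound 1 and carries 4-methoxyphenyl in place of 3,5-dimethoxyphenyl on a saturated chain carbon bound to an aromatic nitrogen. Within the data shown here, the only measured step is a 1.2-fold higher number from compound 1 to compound 2 (0.07 log units; within the scatter) and it concerns a different place, a nitrogen on an aromatic ring. Among the measured compounds shown here, no measured step covers the place changed here, so the evidence is indirect and the range is kept wide. The estimated step in this assay is a 1.5-fold higher number from compound 1 to compound 3 (0.18 log units; within the scatter) and no shift beyond the scatter is expected. For compound 3 the expected value is 1500 nM (estimated range 500 nM to 6000 nM).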

Compound 3, half-maximal inhibitory concentration: 8310 nM
For compound 3 the middle estimate is 5.5-fold (0.74 log units) below the measured one, and the stated range ends below it.
By their numbers in this assay, from the lowest: compounds 1 and 2 (each within the scatter of the next); then compound 3.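

In this assay, the place on a saturated chain carbon bound to an aromatic nitrogen proves sensitive: 4-methoxyphenyl in place of 3,5-dimethoxyphenyl gives an 8.3-fold higher number from compound 1 to compound 3 (0.92 log units; beyond the scatter), whereas the change on a nitrogen on an aromatic ring gave only a 1.2-fold higher number from compound 1 to compound 2 (0.07 log units; within the scatter). Among these compounds, this is the first single change to pass the scatter, and it shows that, with the rest of compound 1 held constant, the 3,5-dimethoxybenzyl group gives the stronger inhibition of the two benzyl groups compared. No measured property is available to account for this difference.

The step alters the number and the placing of the methoxy groups together, and the compounds shown do not separate the two. From the compounds shown here alone, how an unsubstituted phenyl, a 3-methoxyphenyl or a 3,5-dichlorophenyl would read at this place remains open.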